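The compounds below may be only part of what the source reports. "The series", "measured", "known", "first", "only" and "open" are said of these compounds alone.

Compound 1 `O=C(N/N=C/c1cccc(O)c1O)c1ccc(-c2nc3ccccc3s2)cc1` gives 11200 nM in an assay on isolated protein for inhibition of Maltase-glucoamylase (Homo sapiens), with a stated time of 15 min; on this read-out lower numbers stand for stronger inhibition and higher numbers for weaker inhibition. Compound 2 `COC(=O)c1ccc(/C=N/NC(=O)c2ccc(-c3nc4ccccc4s3)cc2)cc1` is reported in this assay as "not active" (no number reported), so compound 2 stands without a number and cannot be placed on the scale. Compound 3 `COc1ccc(/C=N/NC(=O)c2ccc(-c3nc4ccccc4s3)cc2)c(I)c1O` carries 3-hydroxy-2-iodo-4-methoxyphenyl in place of 4-(methoxycarbonyl)phenyl on a carbon with a double bond to nitrogen. Since compound 1, which also bears a hydroxyl on its ring, is weak but measurable in this assay, a shift from no reported activity towards a measurable yet weak result is expected, and its size is uncertain. Compound 3 is estimated at 20000 nM in this assay, within 5000 nM to 100000 nM.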

Compound 3, half-maximal inhibitory concentration: 44800 nM
The estimate for compound 3 lay 2.2-fold (0.35 log units) below the measured number; measured number inside the range.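

In this assay a ring with a single hydroxyl, here 3-hydroxy-2-iodo-4-methoxyphenyl, still gives a number on the carbon with a double bond to nitrogen: exchanging 2,3-dihydroxyphenyl for it gives a 4.0-fold higher number from compound 1 to compound 3 (0.60 log units; beyond the scatter) and so only a modest loss. The step from compound 2 to compound 3 cannot be read, as compound 2 has no number. Nothing measured here explains the step from the one ring to the other.

Going by these compounds, whether the iodine, the methoxy or the missing hydroxyl carries this step stays open. So does how an amine or a carboxylic acid on this ring would read.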